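A few compounds are considered here, and "the series" means these few. Any claim that something is new, unique, unknown or untested is made for them only; others in the source may bear on it.

Measured compounds:
- Compound 1 `C[C@H](C(=O)N1CCCCC1)N1CCN(S(=O)(=O)c2ccc(C(C)(C)C)cc2)CC1` — in an ADME assay on HepG2 cells (Homo sapiens) for inhibition, with a stated time of 48 h (a higher number here means that more compound is needed for the effect, a lower number that less compound is needed), compound 1 gives > 40000 nM, which is a limit of the assay and not a number.
- Compound 2 `CC(C(=O)N1CCCCCC1)N1CCN(S(=O)(=O)c2ccc(C(C)(C)C)cc2)CC1` — in this assay compound 2 gives > 40000 nM, again a limit of the assay.
- Compound 3 `C[C@@H](C(=O)N1CCC(F)(F)CC1)N1CCN(S(=O)(=O)c2ccc(C(C)(C)C)cc2)CC1` — in this assay compound 3 gives > 40000 nM, also a limit of the assay.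

Where compound 2 stands: only a limit is known for it, and the same holds for the two other measured compounds, so no ordering among compounds 1, 2 and 3 can be drawn. All three sit at the limit of > 40000 nM in this assay, at which 3 of the 3 values shown sit. Among the measured compounds shown here, no step between measured compounds can be computed from such values.

The next compound is compound 4 `CC(C(=O)N1CCCc2ccccc21)N1CCN(S(=O)(=O)c2ccc(C(C)(C)C)cc2)CC1`. It differs from compound 2 in one place: 1,2,3,4-tetrahydroquinolin-1-yl in place of azepan-1-yl on a carbonyl carbon. The shared core and the sulfonyl-bearing part of compound 2 stay unchanged.

Since every measured compound reaches only the limit, the size of a step from compound 2 to compound 4 in this assay cannot be read from the data. The expectation is that compound 4 will again sit at or near the same limit, with the step from compound 2 to compound 4 estimated as a number no higher from compound 2 to compound 4 (the limit leaves the size open), which is none beyond the scatter. Compound 4 is therefore estimated at 40000 nM in this assay, with a range from 12000 nM to 120000 nM.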

Compound 4, half-maximal effective concentration: > 40000 nM
Compound 4: no number, only a limit; the forecaster's own chance of this, stated with the estimate: 75%; the middle value lies on the limit itself.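

Among the compounds shown here, no step from compound 2 to compound 4 can be read in this assay, as both values are limits of the assay and not numbers. The series sits at a single value: the limit of > 40000 nM in this assay, at which 4 of the 4 values shown sit.

The compounds shown leave open how compounds 1, 2, 3 and 4 rank in this assay, and what size any difference between them has.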